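A Fluoro for Methyl Swap on the Sulfonyl Ring

This account rests on a few compounds, and the source may have more. Where it says the series, first, only, none or still open, it means among the compounds named here.

Within the data shown here, compound 2 `Cc1ccc(S(=O)(=O)NC(=O)/C=C/c2ccc(F)cc2)cc1` gives 4.8 ug/mL in a functional assay on B16-F10 cells (Mus musculus) for antiproliferative activity, read by ELISA and MTT assay, with a stated time of 48 h (on this read-out higher numbers stand for weaker inhibition and lower numbers for stronger inhibition), the highest of the two numbers measured so far; its nearest neighbour is compound 1 `O=C(/C=C/c1ccc(F)cc1)NS(=O)(=O)c1ccccc1`, which gives 2.1 ug/mL. Among the measured compounds shown here, the single step measured so far, a 2.3-fold higher number from compound 1 to compound 2 (0.36 log units; beyond the scatter), came from placing methyl on an aromatic carbon. Compound 3 `O=C(/C=C/c1ccc(F)cc1)NS(=O)(=O)c1ccc(F)cc1` has not yet been measured; it differs from compound 2 as follows: fluoro in place of methyl on an aromatic carbon. For the measured compounds named here, no measured pair shows fluoro set against methyl directly, so the only guide is the modest size of that one step, which suggests that swapping a small group on this ring moves the number only mildly. Compound 3 is therefore expected to sit between its two neighbours, with a step of a 1.6-fold lower number from compound 2 to compound 3 (0.20 log units; within the scatter), and its estimated value is 3 ug/mL, most likely within 1.5 ug/mL to 6 ug/mL.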

Compound 3, half-maximal inhibitory concentration: 0.8 ug/mL
Estimate against measurement, compound 3: 3.8-fold (0.57 log units) above; measured number below the stated range.
By their numbers in this assay, from the lowest: compound 3; then compound 1; then compound 2.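

In this assay, the place para to a large group on this ring turns out to move the number in both directions, not only upward as the methyl step alone suggested. Fluoro in place of hydrogen gives a 2.6-fold lower number from compound 1 to compound 3 (0.42 log units; beyond the scatter) and so runs opposite to that methyl step, which makes hydrogen's compound 1 the middle of the three. Going from 4-methylphenyl to 4-fluorophenyl gives a 6.0-fold lower number from compound 2 to compound 3 (0.78 log units; beyond the scatter) and spans the whole range of this small set, although only one heavy atom changes.

From the compounds shown here alone, whether chloro, methoxy, an amine or a carboxylic acid at this place would follow fluoro or methyl remains open, as does the effect of fluoro elsewhere on the ring. No measurement at hand offers a reason for the contrast of fluoro with methyl.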